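The source may hold more compounds than are shown below. What is called first, only, known or untested is meant among the compounds shown, and "the series" means these compounds.

The measured compounds and their values:

Compound 1, `COc1cc(/C=C/C(=O)OCCCO[N+](=O)[O-])ccc1OCCCO[N+](=O)[O-]`, gives 3620 nM in a functional assay on HeLa cells (Homo sapiens) for cytotoxicity, read by resazurin assay, with a stated time of 72 h; on this read-out higher numbers stand for weaker inhibition and lower numbers for stronger inhibition.
Compound 2, `O=C(/C=C/c1ccc(O)c(O)c1)OCc1c(-c2ccccc2)no[n+]1[O-]`, gives 1230 nM in this assay.
Compound 3, `COc1cc(/C=C/C(=O)OCc2c(-c3ccccc3)no[n+]2[O-])ccc1O`, gives 7820 nM in this assay.

Compound 2 and compound 3 share a core and differ in one place only. The change from compound 3 to compound 2 is described here: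

hydrogen in place of methyl on an oxygen on an aromatic ring

That change gave a 6.4-fold lower number from compound 3 to compound 2 (0.80 log units; beyond the scatter), so the loss of the methyl went with a stronger inhibition of cell growth.

Compound 4, `O=C(/C=C/c1ccc(OCCCO[N+](=O)[O-])c(O)c1)OCCCO[N+](=O)[O-]`, has not been measured yet. It is built on the core of compound 1, and the two differ in one place:

hydrogen in place of methyl on an oxygen on an aromatic ring

Among the measured compounds shown here, this is the same change as the one from compound 3 to compound 2, and the place where it happens reads the same in both pairs. The cores of compound 1 and compound 3 are not the same; the difference between the two cores is not broken down here.

For the measured compounds named here, only one earlier example of this change is available, so the expectation rests on that single step from compound 3 to compound 2 together with the value of compound 1, 3620 nM. Taking that step as the guide, while allowing that a second core need not answer to the same degree, the step from compound 1 to compound 4 is expected to be a 3.3-fold lower number from compound 1 to compound 4 (0.52 log units; beyond the scatter). On that basis compound 4 is estimated to give 1100 nM in this assay, with a likely range from 400 nM to 3500 nM.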

Compound 4, half-maximal inhibitory concentration: > 50000 nM
Compound 4: a limit, no number; the forecaster's own chance of this, stated with the estimate: 5%; at least 45-fold (1.65 log units) between middle value and limit.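

Compound 4 gives > 50000 nM in this assay, and this is a limit of the assay, not a number. The swap of methoxy to hydroxy therefore did not carry over from one core to the other, since it now goes with an at least 13-fold higher number from compound 1 to compound 4 (1.14 log units; beyond the scatter), in the opposite direction to the earlier step, and the two steps clearly differ: the same change on two cores in this assay, a 6.4-fold lower number (0.80 log units; beyond the scatter) from compound 3 to compound 2 and an at least 13-fold higher number (1.14 log units; beyond the scatter) from compound 1 to compound 4, at least 87-fold (1.94 log units) apart, beyond the scatter of two such steps. This shows that, in these two pairs, the effect of the change depends on the core it sits on, so a result from one core was a poor guide to the other; it does not show which feature of the cores is responsible, how large the step from compound 1 truly is, or how the change would behave on any third core.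

With only two pairs in hand, the compounds shown leave open which part of the core decides the direction of the effect, and a matched pair that varies only the ester side would help to settle it. They also leave open what a longer chain, such as ethyl, would do on that oxygen on the aromatic ring, and how an amide would compare in place of the ester.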